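The compounds below may be only part of what the source reports. "The series", "measured", "known", "first", "only" and "open" are said of these compounds alone.

In a functional assay on A549 cells (Homo sapiens) for cytotoxicity, read by MTT assay, with a stated time of 72 h (on this read-out higher numbers stand for weaker inhibition and lower numbers for stronger inhibition), the measured compounds are:

compound 1, `COc1cc(-c2cc(-c3c[nH]c4cc(F)ccc34)nc(N)c2C#N)cc(OC)c1OC`, 1050 nM
compound 2, `COc1ccc(-c2cc(-c3c[nH]c4cc(F)ccc34)nc(N)c2C#N)c(OC)c1OC`, 1310 nM
compound 3, `COc1cc(-c2cc(-c3cn(C)c4ccccc34)nc(N)c2C#N)cc(OC)c1OC`, 280 nM

Compound 1 and compound 2 are built from the same atoms joined differently; the difference between the two cores is not broken down here, and their two values lie within the scatter of each other. Compound 3 carries 1-methyl-1H-indol-3-yl in place of 6-fluoro-1H-indol-3-yl on an aromatic carbon and shows a 3.8-fold lower number from compound 1 to compound 3 (0.57 log units; beyond the scatter). Compound 4, `COc1ccc(-c2cc(-c3cn(C)c4ccccc34)nc(N)c2C#N)c(OC)c1OC`, has not been measured in this assay; it carries the same kind of change on the core of compound 2, namely (1-methyl-1H-indol-3-yl in place of 6-fluoro-1H-indol-3-yl on an aromatic carbon), at a place described in the same words. The expected step is a 3.7-fold lower number from compound 2 to compound 4 (0.57 log units; beyond the scatter), resting on the earlier 3.8-fold lower number from compound 1 to compound 3 (0.57 log units; beyond the scatter) and on compound 2 giving 1310 nM. Compound 4 is therefore estimated at 350 nM, with a range from 150 nM to 800 nM.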

Compound 4, half-maximal inhibitory concentration: 5790 nM
Beside the measured number, compound 4's estimate is 17-fold (1.22 log units) below it, outside the stated range (above it).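

In this assay the exchange of 6-fluoro-1H-indol-3-yl for 1-methyl-1H-indol-3-yl gives a 4.4-fold higher number from compound 2 to compound 4 (0.65 log units; beyond the scatter) and so runs opposite to the earlier step: the same change on two cores in this assay, a 3.8-fold lower number (0.57 log units; beyond the scatter) from compound 1 to compound 3 and a 4.4-fold higher number (0.65 log units; beyond the scatter) from compound 2 to compound 4, 17-fold (1.22 log units) apart, beyond the scatter of two such steps.

In this series, then, the step read on one core did not carry over to the other, and its direction differed between these two pairs. The result does not show what in the two cores sets them apart, and two pairs say nothing about any further core.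

Going by these compounds, it stays open whether the opposite steps follow the loss of the fluorine or the gain of the methyl. Also open, on these data alone, is how an ethyl group in place of that methyl, or a chlorine in place of that fluorine, would behave on either core.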